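The compounds below may be only part of what the source reports. "The series", "measured", "known", "first", "only" and "open" are said of these compounds alone.

Measured in an assay for inhibition of kynurenine 3-monooxygenase (Homo sapiens), read by mass spectrometry, with a stated time of 1 h; a higher number here means a weaker inhibitor, a lower number a stronger inhibitor:
compound 1 `O=C(O)CCn1c(=O)oc2cc(Cl)c(Cl)cc21`: 6.31 nM
compound 2 `CC(C)Cc1cc2oc(=O)n(CCC(=O)O)c2cc1Cl`: 12.6 nM
compound 3 `O=C(O)CCn1c(=O)oc2cc(OCc3ccccn3)c(Cl)cc21`: 3.16 nM

Compound 3 stands at the low end of these three numbers. The step of a 2.0-fold lower number from compound 1 to compound 3 (0.30 log units; within the scatter) is within the scatter, so compound 1 and compound 3 cannot be told apart on this assay, whereas the step of a 4.0-fold lower number from compound 2 to compound 3 (0.60 log units; beyond the scatter) is beyond the scatter; the step of a 2.0-fold higher number from compound 1 to compound 2 (0.30 log units; within the scatter) between the other two is itself within the scatter.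

Compound 4 `C[C@@H](Oc1cc2oc(=O)n(CCC(=O)O)c2cc1Cl)c1ncccn1` is not yet measured. It differs from compound 3 in one place: a group of 8 heavy atoms (6 carbon, 2 nitrogen; one six-membered aromatic ring with 2 hetero atoms) in place of a group of 7 heavy atoms (6 carbon, 1 nitrogen; one six-membered aromatic ring with 1 hetero atom), on an oxygen on an aromatic ring. The two measured steps that touch this position both end at compound 3 and both replace a different group with the (pyridin-2-yl)methoxy group; neither swaps a ring with one hetero atom for a ring with two, and neither introduces a defined stereocentre. Within the data shown here, no measured step tests that exchange. Since changes at this position have moved this assay only within the scatter or modestly, no step beyond the scatter is expected for a 1.3-fold higher number from compound 3 to compound 4 (0.10 log units; within the scatter). Compound 4 is therefore estimated at 4 nM in this assay, with an expected range from 1.5 nM to 12 nM.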

Compound 4, half-maximal inhibitory concentration: 5.01 nM
The estimate for compound 4 lay 1.3-fold (0.10 log units) below the measured number, within the range that was stated.
By their numbers in this assay, from the lowest: compounds 3, 4, 1 and 2 (each within the scatter of the next, the first and the last beyond it).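

In this assay, among these compounds, the exchange on the oxygen on an aromatic ring gives a 1.6-fold higher number from compound 3 to compound 4 (0.20 log units; within the scatter), and this is the first step that keeps the oxygen link and alters only the group carried on it. The earlier steps shown here at this position replaced chloro or isobutyl with the (pyridin-2-yl)methoxy group, whereas this one shows that a six-membered aromatic ring with 2 hetero atoms and 1 defined stereocentre can replace (pyridin-2-yl)methyl with no change that can be told apart from the scatter, leaving compound 3 and compound 4 indistinguishable in this assay. No supporting data bear on this result.

The ring exchange and the defined stereocentre arrive together in this single step, so the compounds shown leave their separate contributions open, and the same holds for the opposite configuration at that stereocentre. As far as these compounds go, it also remains open how this assay responds when the group on this oxygen is something other than an aromatic ring, such as an amine or a longer chain.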